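The compounds below may be only part of what the source reports. "The series", "measured", "known", "first", "only" and "open" are said of these compounds alone.

Compound 1 `COc1cc(Cl)cc(-c2nn(-c3cccc(NC(=O)Nc4ccc(Cl)c(C(F)(F)F)c4)c3)cc2-c2ccncc2)c1`, compound 2 `COc1cc(Cl)cc(-c2nn(-c3cccc(NC(=O)Nc4ccc(Cl)c(Cl)c4)c3)cc2-c2ccncc2)c1` and compound 3 `COc1cc(Cl)cc(-c2nn(-c3cccc(NC(=O)Nc4cccc(C(F)(F)F)c4)c3)cc2-c2ccncc2)c1` share one core and differ only in the substituents of one outer aromatic ring. In a functional assay on SF-295 cells (Homo sapiens) for inhibition, read by sulforhodamine B assay, with a stated time of 48 h, tested at 0.1 uM (a lower number here means a stronger effect, a higher number a weaker effect of the compound at the concentration tested), compound 1 gives 98%, compound 2 gives 57% and compound 3 gives 57%. Putting chloro in place of trifluoromethyl gives a number 41 percentage points lower from compound 1 to compound 2 (beyond the scatter), and putting hydrogen in place of chloro gives a number 41 percentage points lower from compound 1 to compound 3 (beyond the scatter), while between the two lower compounds there is no change at the digits printed from compound 2 to compound 3 (within the scatter). Compound 3 therefore stands level with compound 2, the pair together the lowest of the three numbers, and furthest from compound 1.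

Compound 4 `COc1cc(Cl)cc(-c2nn(-c3cccc(NC(=O)c4cccc(C(F)(F)F)c4)c3)cc2-c2ccncc2)c1` differs from compound 3 by 3-(trifluoromethyl)phenyl in place of (3-(trifluoromethyl)phenyl)amino on a carbonyl carbon. Among the measured compounds shown here, none of the three measured steps touches the carbonyl or its neighbours; all of them vary substituents on the ring that is retained, so no measured step bears on this change and the numbers give no direction for it. Compound 4 is estimated at 65% in this assay, with a range from 35% to 95%. The expected step is a number 8 percentage points higher from compound 3 to compound 4 (within the scatter), an uncertain one either way.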

Compound 4, a percentage reported as activity, at one concentration (the size of the read-out at that concentration, not a potency): 90%
Estimate against measurement, compound 4: 25 percentage points below; the range from low to high includes it.
By their numbers in this assay, from the lowest: compounds 2 and 3 (each within the scatter of the next); then compounds 4 and 1 (each within the scatter of the next).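

In this assay, among the compounds shown here, the earlier compounds varied only the ring substituents, and this result shows that the group on the carbonyl carbon also matters. With the 3-(trifluoromethyl)phenyl ring kept, removing the amino nitrogen and the amide hydrogen it carries gives a large step (a number 33 percentage points higher from compound 3 to compound 4 (beyond the scatter)), and the comparison with the dichloro compound gives a step of the same printed size (a number 33 percentage points higher from compound 2 to compound 4 (beyond the scatter)). Compound 4 therefore falls with compound 1 rather than with the two lower compounds (a number 8 percentage points lower from compound 1 to compound 4 (within the scatter)). No evidence is available to explain this change.

As far as these compounds go, it remains open whether a methylene or an ether oxygen on the carbonyl carbon, in place of the amino nitrogen, would stay level with compound 3. From the compounds shown here alone, the same replacement with a 3,4-dichlorophenyl or 4-chloro-3-(trifluoromethyl)phenyl ring also remains open.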